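This account rests on a few compounds, and the source may have more. Where it says the series, first, only, none or still open, it means among the compounds named here.

Of the compounds shown here, three have been measured in an assay on isolated protein for inhibition of Rho-associated protein kinase 1 (Homo sapiens), tested at 30 uM; on this read-out lower numbers stand for less inhibition and higher numbers for more inhibition at the one concentration tested (going by the name of the read-out). Compound 1, with the structure `c1ccc(-[n+]2c[nH]c3ncncc32)cc1`, gives 0%. Compound 2, with the structure `Clc1ncnc2ncn(Cc3ccccc3)c12`, gives 6%. Compound 3, with the structure `Fc1ccc(Cn2cnc3ncnc(Cl)c32)cc1`, gives 7%. On these numbers compound 3 holds the highest of the three values, although its gap to compound 2 and its gap to compound 1 both lie within the usual scatter, so the three compounds cannot be ranked. Among the compounds with values here, the only one-place step measured so far is a number 1 percentage points higher from compound 2 to compound 3 (within the scatter).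

Compound 4, with the structure `COc1ncnc2ncn(Cc3ccc(F)cc3)c12`, has not been measured yet. It differs from compound 3 as follows: methoxy in place of chloro on an aromatic carbon. No measured step shows a methoxy in place of a chloro, so the step from compound 2 to compound 3 does not bear on this change directly, and the three measured values offer no reason to expect a move beyond the scatter in this assay. The expected step is therefore a number 2 percentage points lower from compound 3 to compound 4 (within the scatter). Compound 4 is estimated at 5%, with a range from 0% to 15%.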

Compound 4, a percentage reported as inhibition, at one concentration (the size of the read-out at that concentration, not a potency): 1%
The estimate for compound 4 lay 4 percentage points above the measured number; measured number inside the range.
By their numbers in this assay, from the lowest: compounds 1, 4, 2 and 3 (each within the scatter of the next).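

In this assay, the change at this aromatic carbon gives a number 6 percentage points lower from compound 3 to compound 4 (within the scatter), so putting methoxy, with its 1 hydrogen-bond acceptor, in place of chloro does not move the number beyond the scatter. Within the data shown here, the earlier step, a number 1 percentage points higher from compound 2 to compound 3 (within the scatter), was a fluoro change elsewhere in the molecule, so this is the first reading at this position, and it shows no sign that chloro is needed here or that methoxy helps. No outside data bear on this result.

On these data alone, whether an amine or a longer chain on this same aromatic carbon would carry the number beyond the scatter remains open. As far as these compounds go, with all four compounds within the scatter of their neighbours, it is also open which parts of the shared core matter for this read-out.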